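Swapping a cyanophenyl for a short branched alkenyl chain

A few compounds are considered here, and "the series" means these few. Any claim that something is new, unique, unknown or untested is made for them only; others in the source may bear on it.

Compound 1, `Fc1ccccc1Cn1ccc2nc(-c3ccccc3)nc-2c1`, in an ADME assay on MDBK cells (Bos taurus) for cytotoxicity (on this read-out higher numbers stand for lower toxicity in this test and lower numbers for higher toxicity in this test), gives > 100000 nM, which is a limit of the assay and not a number.
Compound 2, `Brc1ccccc1Cn1ccc2nc(-c3ccccc3)nc-2c1`, in this assay gives > 100000 nM, again a limit.
Compound 3, `N#Cc1cccc(Cn2ccc3nc(-c4ccccc4)nc-3c2)c1`, in this assay gives > 100000 nM, also a limit.

Compound 3 therefore stands exactly where the other two measured compounds stand: all three sit at the limit of > 100000 nM in this assay, at which 3 of the 3 values shown sit, and no one of them can be placed above or below another. The steps among them, a step that the two limits leave unreadable from compound 1 to compound 2, a step that the two limits leave unreadable from compound 1 to compound 3 and a step that the two limits leave unreadable from compound 2 to compound 3, are unreadable in size for that reason, since each end rests on the same limit.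

Compound 4, `CC(C)=CCn1ccc2nc(-c3ccccc3)nc-2c1`, differs from compound 3 in one place: 2-methylprop-1-en-1-yl in place of 3-cyanophenyl on a saturated chain carbon bound to an aromatic nitrogen. Among the compounds with values here, the measured steps that touch the same place, the step from compound 1 to compound 3 and the step from compound 2 to compound 3, exchange one aromatic group for another and give no readable size; none of the measured steps trades an aromatic ring for an open chain. The data thus offer no size for the present change, and the expected step is a number no higher from compound 3 to compound 4 (the limit leaves the size open), nothing beyond the scatter. Compound 4 is accordingly estimated at 100000 nM, within 40000 nM to 250000 nM, and is most likely to be reported once more only as a limit.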

Compound 4, half-maximal cytotoxic concentration: > 100000 nM
Compound 4: no number, only a limit; the forecaster's own chance of this, stated with the estimate: 80%; the middle value lies on the limit itself.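

Compound 4 stands with compound 1, compound 2 and compound 3 on the same limit in this assay, so none of its steps to those three can be read: the limit of > 100000 nM in this assay, at which 4 of the 4 values shown sit.
The compounds shown leave open how these four compare with one another, and whether any group on the saturated chain carbon bound to an aromatic nitrogen would give a measurable number in this assay at all.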